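Dichlorophenyl for Aminophenyl in a Guinea-Pig Tissue Assay

The compounds below may be only part of what the source reports. "The series", "measured", "known", "first", "only" and "open" are said of these compounds alone.

Compound 1 `COC(=O)C1=C(C)N=C(C)/C(=C(\O)OC)C1c1cccc(N)c1` is the reference point. Among the measured compounds shown here, in a functional assay (muscle tissue) with Cavia porcellus as the target (a higher number here means that more compound is needed for the effect, a lower number that less compound is needed), compound 1 gives 2000 nM, the second highest of the three numbers measured so far: compound 2 `COC(=O)C1=C(C)N=C(C)/C(=C(\O)OC)C1c1cccc(C(F)(F)F)c1` gives 74.1 nM, while compound 3 `COC(=O)C1=C(C)N=C(C)/C(=C(\O)OC)C1c1cccc([N+](C)(C)C)c1` gives 50100 nM. The measured steps pull in opposite directions. The step of a 27-fold lower number from compound 1 to compound 2 (1.43 log units; beyond the scatter) is large and downward, the step of a 25-fold higher number from compound 1 to compound 3 (1.40 log units; beyond the scatter) is large and upward, and the step of a 680-fold higher number from compound 2 to compound 3 (2.83 log units; beyond the scatter) spans the whole set.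

Compound 4 `COC(=O)C1=C(C)N=C(C)/C(=C(\O)OC)C1c1c(Cl)cccc1Cl` has not yet been measured. Against compound 1 the change is 2,6-dichlorophenyl in place of 3-aminophenyl on a saturated ring carbon. For the measured compounds named here, no measured step exchanges the whole aryl group in this way, so only the general picture from compound 1 guides the expectation, and of the two measured steps the halogen-bearing change in a 27-fold lower number from compound 1 to compound 2 (1.43 log units; beyond the scatter) resembles the present one more than the change in a 25-fold higher number from compound 1 to compound 3 (1.40 log units; beyond the scatter). A large downward step a 50-fold lower number from compound 1 to compound 4 (1.70 log units; beyond the scatter) in this assay is therefore expected, though with wide uncertainty. Compound 4 is estimated to give 40 nM, within a range from 5 nM to 400 nM.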

Compound 4, half-maximal effective concentration: 1.91 nM
The estimate for compound 4 lay 21-fold (1.32 log units) above the measured number, and the stated range ends above it.
By their numbers in this assay, from the lowest: compound 4; then compound 2; then compound 1; then compound 3.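

In this assay, the step of a 1000-fold lower number from compound 1 to compound 4 (3.02 log units; beyond the scatter) is the largest in the set, so exchanging the whole aryl group on this saturated ring carbon moves the number further than any change shown so far. Compound 4, at 1.91 nM, now marks the low end of the series, below compound 2 at 74.1 nM. Nothing available accounts for the size of this step.

The change removes the amino group and brings in two chlorine atoms at once, so the compounds shown cannot separate the share of each. As far as these compounds go, it remains open how a phenyl group bearing a single chlorine, a nitro group or a methoxy group would read, and whether 2,6-dichlorophenyl would hold its number with an ester carrying a longer chain in place of methoxycarbonyl.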